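The compounds below may be only part of what the source reports. "The series", "measured", "known", "first", "only" and "open" are said of these compounds alone.

Of the compounds shown here, two of this set have so far been measured in a physicochemical assay for solubility, read by LC-MS, in phosphate buffer, measured as kinetic solubility, with a stated time of 24 h, at 25 degrees C, at pH 7.4; a higher number here means a more soluble compound, a lower number a less soluble compound. Compound 1 `Nc1cc(-c2ccc3c(N)n[nH]c3c2)nc(N)n1` gives 58000 nM in this assay, and compound 2 `Nc1nccc(-c2ccc3c(Nc4ccccc4)n[nH]c3c2)n1` gives 3000 nM. Among the measured compounds shown here, compound 2 thus stands lowest of the two numbers known; its only neighbour is compound 1, whose number is higher by a margin well beyond the usual scatter. Compound 3 `Nc1nccc(-c2ccc3c(NCc4ccccc4)n[nH]c3c2)n1` has not yet been measured in this assay. It differs from compound 2 in one place: benzyl in place of phenyl on a nitrogen on an aromatic ring, which, cut one bond further out, reads anilino to benzylamino. For the measured compounds named here, no step between two measured compounds isolates this change, so the data give no direct guide to its size or direction. The expected step of a 1.3-fold higher number from compound 2 to compound 3 (0.12 log units; within the scatter) is therefore small, not beyond the scatter, and is set as a slight rise only tentatively. Compound 3 is expected to give about 4000 nM in this assay, with a likely range from 1500 nM to 12000 nM.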

Compound 3, solubility: 17000 nM
Compound 3: middle estimate off by 4.3-fold (0.63 log units), on the low side; measured number above the stated range.
By their numbers in this assay, from the lowest: compound 2; then compound 3; then compound 1.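

In this assay, among the compounds shown here, the change of benzyl in place of phenyl on a nitrogen on an aromatic ring gives a 5.7-fold higher number from compound 2 to compound 3 (0.75 log units; beyond the scatter) and is the first single change in this set that can be read. The group at this place therefore matters for this read-out, even though the two groups carry the same six-membered aromatic ring of carbon only and the same counts of hydrogen-bond donors and acceptors. Nothing available here accounts for the rise. On these data alone, whether it continues with phenethyl on the same nitrogen, or persists when the benzyl carries a carboxylic acid or an amine, stays open. Also open, as far as these compounds go, is whether anilino to benzylamino would give a step of similar size on the core of compound 1.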